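A few compounds are considered here, and "the series" means these few. Any claim that something is new, unique, unknown or untested is made for them only; others in the source may bear on it.

In a functional assay on HeLa cells (Homo sapiens) for inhibition, read by MTT assay, with a stated time of 48 h (a higher number here means a weaker inhibitor, a lower number a stronger inhibitor), compound 1 `CCOC(=O)C1=C(N/C=N/c2cccnc2Cl)Nc2[nH]nc(C)c2C1c1ccc(N(C)C)cc1` gives 4630 nM, compound 2 `CCOC(=O)C1=C(N/N=C(\c2ccc([N+](=O)[O-])cc2)N2CCN(c3ccc(F)cc3)CC2)Nc2[nH]nc(C)c2C1c1ccc(N(C)C)cc1` gives 87000 nM and compound 3 `CCOC(=O)C1=C(N/N=C(/C(=O)Br)c2ccc(Br)cc2)Nc2[nH]nc(C)c2C1c1ccc(N(C)C)cc1` gives 68500 nM. Compound 3 and compound 2 lie within the scatter of each other, at the weak end of these three numbers, while compound 1 stands clearly apart. Compound 4 `CCOC(=O)C1=C(N)Nc2[nH]nc(C)c2C1c1ccc(N(C)C)cc1` carries a hydrogen atom in place of a group of 12 heavy atoms (8 carbon, 1 nitrogen, 1 oxygen, 2 bromine; one six-membered aromatic ring of carbon only), on an amine nitrogen. For the measured compounds named here, no measured compound has only hydrogen at this nitrogen, so the evidence is indirect. Going by the values given here, the one measured step at this nitrogen, a 15-fold higher number from compound 1 to compound 3 (1.17 log units; beyond the scatter), shows that the group there can move the number widely. A downward move of smaller size is therefore expected in this assay, with wide uncertainty. The expected step is a 2.7-fold lower number from compound 3 to compound 4 (0.44 log units; beyond the scatter). For compound 4 the estimated value is 25000 nM, with an estimated range of 6000 nM to 90000 nM.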

Compound 4, half-maximal inhibitory concentration: 6220 nM
Beside the measured number, compound 4's estimate is 4.0-fold (0.60 log units) above it; low and high end bracket the measured number.
By their numbers in this assay, from the lowest: compounds 1 and 4 (each within the scatter of the next); then compounds 3 and 2 (each within the scatter of the next).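

In this assay the loss of the whole group from the amine nitrogen gives an 11-fold lower number from compound 3 to compound 4 (1.04 log units; beyond the scatter) and so removes the weak number, which shows that this nitrogen needs no substituent to reach the low end of the series. Hydrogen and the group of 9 heavy atoms give a 1.3-fold higher number from compound 1 to compound 4 (0.13 log units; within the scatter) and are not separated here, so the large group of compound 1 adds nothing measurable over hydrogen. Nothing at hand explains the size of either step.

On these data alone, whether a small group on this nitrogen, such as acetyl or methyl, stays level with hydrogen remains open. Also open, as far as these compounds go, is which part of the groups in compound 2 and compound 3 goes with their weak numbers.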